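The source may hold more compounds than are shown below. What is called first, only, known or untested is meant among the compounds shown, and "the series" means these compounds.

Measured so far in a functional assay on the whole organism with Rattus norvegicus as the target, at a dose of 20 mg/kg by the intraperitoneal route; on this read-out lower numbers stand for less inhibition and higher numbers for more inhibition at the one dose given (going by the name of the read-out):
compound 1 `CS(=O)(=O)c1cccc(-c2nc(N)nc(N)n2)c1` gives -6%
compound 2 `Nc1nc(N)nc(-c2cccc(Br)c2)n1` gives 96%

Compound 2 stands highest of the two numbers available; its nearest neighbour is compound 1, which lies far lower, the step of a number 102 percentage points higher from compound 1 to compound 2 (beyond the scatter) going with bromo in place of methylsulfonyl on an aromatic carbon. Compound 3 `Nc1nc(N)nc(-c2cccc(C(F)(F)F)c2)n1` keeps the shared core and differs from compound 2 in one place: trifluoromethyl in place of bromo on an aromatic carbon.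

Going by the values given here, no measured step exchanges bromo for trifluoromethyl, so the single step at hand, a number 102 percentage points higher from compound 1 to compound 2 (beyond the scatter), bears on the question only indirectly: it shows that a change at this aromatic carbon can move the read-out across nearly its whole span, but it does not say how bromo and trifluoromethyl compare. In the absence of a closer precedent, compound 3 is expected to fall somewhat short of compound 2, by a step of a number 21 percentage points lower from compound 2 to compound 3 (beyond the scatter), with wide uncertainty in either direction. Compound 3 is therefore estimated at 75% in this assay, in a range from 30% to 100%.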

Compound 3, a percentage reported as inhibition, in the whole organism at one dose (the size of the read-out at that dose, not a potency): 81%
Estimate against measurement, compound 3: 6 percentage points below, and the stated range covers the measured number.
By their numbers in this assay, from the lowest: compound 1; then compound 3; then compound 2.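

In this assay, trifluoromethyl in place of bromo on this aromatic carbon gives a number 15 percentage points lower from compound 2 to compound 3 (beyond the scatter) and counts as a modest change, so the two groups are not interchangeable here, yet both keep the read-out high. Trifluoromethyl in place of methylsulfonyl gives a number 87 percentage points higher from compound 1 to compound 3 (beyond the scatter) and closely matches the large rise seen with bromo, which shows that high inhibition at this position does not depend on bromo alone. Among these compounds, methylsulfonyl is the one group that goes with a low read-out, and no accompanying measurement bears on why these steps take the sizes they do.

From the compounds shown here alone, whether a chloro, a methyl, a methoxy, an amine or a carboxylic acid on this same carbon would stay close to bromo and trifluoromethyl or drop toward methylsulfonyl remains open. A read-out taken at one dose also leaves open how these compounds would compare at other doses, so the numbers describe the size of the effect at that dose and not potency.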